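This account rests on a few compounds, and the source may have more. Where it says the series, first, only, none or still open, it means among the compounds named here.

Compound 1 `O=C(Nc1ccc(Cl)c(-c2nnc3c(Cl)cccn23)c1)c1ccc(F)cc1Cl` in a functional assay on HeLa cells (Homo sapiens) for antiproliferative activity, read by MTT assay, with a stated time of 72 h (on this read-out higher numbers stand for weaker inhibition and lower numbers for stronger inhibition), gives > 100000 nM, which is a limit of the assay and not a number.
Compound 2 `O=C(Nc1ccc(Cl)c(-c2nnc3c(Cl)cccn23)c1)c1cccnc1` in this assay gives > 100000 nM, again a limit.
Compound 3 `CS(=O)(=O)c1ccc(C(=O)Nc2ccc(Cl)c(-c3nnc4c(Cl)cccn34)c2)cc1` in this assay gives > 100000 nM, again a limit.

Compound 1 therefore stands at the limit of this assay, with no measured number of its own, and the same holds for compound 2 and compound 3, as the limit of > 100000 nM in this assay, at which 3 of the 3 values shown sit, records. Compound 4 `O=C(Nc1ccc(Cl)c(-c2nnc3c(Cl)cccn23)c1)c1ccon1` keeps the shared core of compound 1 and alters the group on the carbonyl carbon: 1,2-oxazol-3-yl in place of 2-chloro-4-fluorophenyl on a carbonyl carbon. The measured steps that bear on such a change at the carbonyl carbon are a step that the two limits leave unreadable from compound 1 to compound 2 and a step that the two limits leave unreadable from compound 1 to compound 3, both of which cannot be read in size or direction because every value involved sits at the limit of > 100000 nM in this assay, at which 3 of the 3 values shown sit. Two earlier exchanges of the group on the carbonyl carbon left the read-out at the limit, so no readable step is expected for compound 4 either, and it is estimated to remain at or near that limit. Compound 4 is expected to give about 150000 nM, in the range 30000 nM to 600000 nM. The step from compound 1 that this estimate implies is a step that the limit leaves unreadable from compound 1 to compound 4, expected to be unreadable in practice.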

Compound 4, half-maximal inhibitory concentration: > 100000 nM
Compound 4 was reported as a limit; the forecaster's own chance of this, stated with the estimate: 85%; the middle value lies beyond the limit too.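

Compound 4 gives > 100000 nM in this assay, which is again a limit and not a number, so its steps from compound 1, compound 2 and compound 3 cannot be read: the limit of > 100000 nM in this assay, at which 4 of the 4 values shown sit. The compounds shown leave open whether any group on the carbonyl carbon of this shared core can give a measurable value in this assay.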